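This account rests on a few compounds, and the source may have more. Where it says the series, first, only, none or still open, it means among the compounds named here.

Measured in an ADME assay on HepG2 2.2.15 cells (Homo sapiens) for cytotoxicity; a higher number here means that more compound is tolerated, a lower number that less compound is tolerated:
- compound 1 `CCC(=O)OCCc1c(-c2ccccc2Cl)c2cc(Cl)ccc2[nH]c1=O`: 95000 nM
- compound 2 `O=C(OCCc1c(-c2ccccc2Cl)c2cc(Cl)ccc2[nH]c1=O)C1CCCC1`: 46000 nM

Compound 2 holds the lower of the two numbers, at 46000 nM. Compound 3 `O=C(OCCc1c(-c2ccccc2Cl)c2cc(Cl)ccc2[nH]c1=O)C1CCCCC1` has cyclohexyl in place of cyclopentyl on a carbonyl carbon. Going by the values given here, only one measured step bears on this change, a 2.1-fold lower number from compound 1 to compound 2 (0.31 log units; beyond the scatter), which also alters the group on the carbonyl carbon. A single modest step gives weak guidance, so only a small further drop in this assay is expected, and it may stay within the scatter. The expected change is a 1.3-fold lower number from compound 2 to compound 3 (0.11 log units; within the scatter). For compound 3 the estimated value is 36000 nM, with an expected range of 16000 nM to 75000 nM.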

Compound 3, half-maximal cytotoxic concentration: 38000 nM
Compound 3: the middle estimate sits 1.1-fold (0.02 log units) below what was measured; the range from low to high includes it.
By their numbers in this assay, from the lowest: compounds 3 and 2 (each within the scatter of the next); then compound 1.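

In this assay, cyclohexyl in place of cyclopentyl on the carbonyl carbon gives a 1.2-fold lower number from compound 2 to compound 3 (0.08 log units; within the scatter) and so does not separate the two rings. Cyclohexyl in place of ethyl gives a 2.5-fold lower number from compound 1 to compound 3 (0.40 log units; beyond the scatter) and so keeps compound 3, like compound 2, apart from compound 1. Nothing measured explains either step.

The compounds shown leave open whether the number depends on having a carbon ring here or on group size alone. A longer open chain, a phenyl ring or an amine on the carbonyl carbon could test this.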